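Swapping the Aryl Substituent: From Methylsulfanyl to Propyl

This account rests on a few compounds, and the source may have more. Where it says the series, first, only, none or still open, it means among the compounds named here.

Compound 1, `COc1ccccc1N1CCN(CCCNc2ncccc2C(=O)N(C)C)CC1`, gives 1.59 nM in a functional assay for antagonist activity at Alpha-1A adrenergic receptor (Oryctolagus cuniculus); on this read-out higher numbers stand for weaker binding and lower numbers for tighter binding.
Compound 2, `Cc1ccccc1N1CCN(CCCNc2ncccc2C(=O)N(C)C)CC1`, gives 2 nM in this assay.
Compound 3, `CSc1ccccc1N1CCN(CCCNc2ncccc2C(=O)N(C)C)CC1`, gives 0.631 nM in this assay.

Among these three, compound 3 stands at the lowest number: the steps of a 2.5-fold lower number from compound 1 to compound 3 (0.40 log units; beyond the scatter) and a 3.2-fold lower number from compound 2 to compound 3 (0.50 log units; beyond the scatter) both run beyond the scatter, whereas a 1.3-fold higher number from compound 1 to compound 2 (0.10 log units; within the scatter) does not. Compound 4, `CCCc1ccccc1N1CCN(CCCNc2ncccc2C(=O)N(C)C)CC1`, has not yet been measured. It differs from compound 3 in one place: propyl in place of methylsulfanyl on an aromatic carbon. Going by the values given here, no measured step puts propyl on this carbon, so the nearest guides are the two steps that lead to compound 3 itself, each showing that methylsulfanyl gave the tightest binding of the three groups tried so far. Replacing it with propyl is therefore expected to raise the number by a modest amount, about a 2.9-fold higher number from compound 3 to compound 4 (0.46 log units; beyond the scatter), although a result within the scatter of compound 3 cannot be ruled out. Compound 4 is accordingly estimated at 1.8 nM, with a likely range from 0.6 nM to 6 nM.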

Compound 4, dissociation constant: 0.2 nM
Compound 4: middle estimate off by 9.0-fold (0.95 log units), on the high side; measured number below the stated range.
By their numbers in this assay, from the lowest: compound 4; then compound 3; then compounds 1 and 2 (each within the scatter of the next).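

Methylsulfanyl is not the best of the groups at this aromatic carbon: in this assay propyl, which has no hydrogen-bond acceptor, gives a 3.2-fold lower number from compound 3 to compound 4 (0.50 log units; beyond the scatter), so tight binding here does not depend on such an acceptor in this group. The gain is larger against the other two groups, with a 10-fold lower number from compound 2 to compound 4 (1.00 log units; beyond the scatter) when methyl is extended to propyl and an 8.0-fold lower number from compound 1 to compound 4 (0.90 log units; beyond the scatter) when methoxy gives way to propyl, which makes compound 4 the tightest binder of the four. No measurement at hand explains why propyl does better.

With methyl and propyl as the only plain carbon chains, two points cannot show how binding follows chain length. A longer butyl chain, a branched isopropyl group or an amine at this carbon could each continue this gain or reverse it.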